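Mirror image of compound 1 in the efflux assay

A few compounds are considered here, and "the series" means these few. Any claim that something is new, unique, unknown or untested is made for them only; others in the source may bear on it.

Working notes on the series. Compound 1 `COCC[C@@H]1C[C@H]1c1cncc(N2CCCNCC2)c1` is the reference point. In an assay on SH-EP1 cells for antagonist activity at Neuronal acetylcholine receptor; alpha4/beta2 (Homo sapiens), read by rubidium efflux, with stated times of 10 min and 5 min (a lower number here means a smaller maximal response, a higher number a larger maximal response), compound 1 gives 79%, the highest of the two numbers available. Compound 2 `OCCc1cc(-c2cncc(N3CCCNCC3)c2)on1` in this assay gives 68%, a number lower than that of compound 1 by a margin beyond the usual scatter. For compound 3 `COCC[C@@H]1C[C@H]1c1cncc(N2C[C@@H]3C[C@H]2CN3)c1` the entry in this assay is "not determined" (no result reported), so it contributes no number. For the measured compounds named here, no pair of measured compounds differs in only one place, so the size of a single change in this assay cannot be read from the measurements themselves.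

Compound 4 `COCC[C@H]1C[C@@H]1c1cncc(N2CCCNCC2)c1` is the next entry. Its difference from compound 1: the two compounds have the same atoms and bonds and differ only in configuration as drawn: 2 of 2 stereo elements differ (all stereocentres are inverted: mirror images); a stereocentre at a saturated ring carbon is drawn S in compound 1 and R in compound 4; a stereocentre at a saturated ring carbon is drawn R in compound 1 and S in compound 4. Neither compound 2 nor compound 3 informs on a mirror image in this assay; both differ from compound 1 elsewhere. A small to moderate step downward is expected, though a step within the scatter cannot be excluded. The expected step is a number 11 percentage points lower from compound 1 to compound 4 (beyond the scatter). Compound 4 is estimated at 68%, with a range from 45% to 92%.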

Compound 4, largest response reached (reported as efficacy), in percent of the reference or control that the assay uses: 74%
Estimate against measurement, compound 4: 6 percentage points below; the measured number falls inside the stated range.
By their numbers in this assay, from the lowest: compounds 2, 4 and 1 (each within the scatter of the next, the first and the last beyond it).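

For the compounds shown here, until now no pair of measured compounds differed in one place only, so this is the first single change that can be sized in this assay: a number 5 percentage points lower from compound 1 to compound 4 (within the scatter). Inverting both stereocentres at the saturated ring carbons therefore produces no change in maximal response that can be told from the scatter, so this assay does not separate the two mirror images. The comparison isolates configuration from every other structural feature: the fact that compounds 1 and 4 differ only in the configuration as drawn.

The pair leaves open what inverting just one of the two stereocentres would do, since here both change together. It also leaves open whether the two mirror images would stay this close if the chain ended in a carboxylic acid or an amine rather than the ether of compound 1.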